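Ethoxy to Methyl on a Carbonyl Carbon: an Expected Half-life

A few compounds are considered here, and "the series" means these few. Any claim that something is new, unique, unknown or untested is made for them only; others in the source may bear on it.

Compound 1 `CN(/N=N/c1ccc(C#N)cc1)C(=O)CCc1ccc(O)cc1` and compound 3 `Cc1ccc(/N=N/N(C)C(=O)CCc2ccc(O)cc2)cc1` differ only on an aromatic carbon. In a physicochemical assay for pharmacokinetics, read by HPLC, in phosphate buffer, at pH 7.4 (on this read-out higher numbers stand for a longer-lived compound and lower numbers for a shorter-lived compound), compound 1 gives 86.4 h, and compound 3 gives 101 h; the step of a 1.2-fold higher number from compound 1 to compound 3 (0.07 log units; within the scatter) lies within the scatter. Compound 2 `CCOC(=O)c1ccc(/N=N/N(C)C(=O)NCCSc2ccc(O)cc2)cc1` has a different core from these two. In this assay compound 2 gives > 240 h, which is a limit of the assay rather than a number. Compound 2 thus sits at the limit of > 240 h in this assay, at which 1 of the 3 values shown sits, the top of the range shown. Compound 4 `CC(=O)c1ccc(/N=N/N(C)C(=O)NCCSc2ccc(O)cc2)cc1` differs from compound 2 by methyl in place of ethoxy on a carbonyl carbon. Among the compounds with values here, the only measured step concerns an aromatic carbon, not a carbonyl carbon, so no measured step bears directly on this change; the expected step in this assay is an at least 1.0-fold lower number from compound 2 to compound 4 (0.03 log units; that floor lies within the scatter), none beyond the scatter. Compound 4 is therefore estimated to give 220 h in this assay, between 80 h and 600 h.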

Compound 4, half-life: > 240 h
Compound 4: no number, only a limit; the forecaster's own chance of this, stated with the estimate: 40%; middle value at least 1.0-fold (0.03 log units) away from the limit.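

Compound 2 and compound 4 each give a limit in this assay, not a number, and no step can be read between them. As far as these compounds go, how far methyl in place of ethoxy on a carbonyl carbon moves the half-life stays open.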